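Piperidin-1-yl Replaces Cyclohexylamino: an Expected Outcome

A few compounds are considered here, and "the series" means these few. Any claim that something is new, unique, unknown or untested is made for them only; others in the source may bear on it.

In a functional assay on PC-3 cells (Homo sapiens) for cytotoxicity, read by sulforhodamine B assay, with a stated time of 72 h (a higher number here means a weaker inhibitor, a lower number a stronger inhibitor), compound 1 `Nc1sc(-c2ccc([N+](=O)[O-])cc2)c(-c2ccc(Cl)cc2)c1C(=O)N1CCCC1` gives 42600 nM. Compound 2 `Clc1ccc(-c2sc3ncnc(NC4CC4)c3c2-c2ccc(Cl)cc2)cc1` reaches only the limit of > 50000 nM. Compound 3 `Clc1ccc(-c2sc3ncnc(NC4CCCCC4)c3c2-c2ccc(Cl)cc2)cc1` likewise reaches only the limit of > 50000 nM. The step that the two limits leave unreadable from compound 2 to compound 3 cannot be read; both of its ends are limits. Compound 3 thus stands at the limit of > 50000 nM in this assay, at which 2 of the 3 values shown sit, with no number of its own. Compound 4 `Clc1ccc(-c2sc3ncnc(N4CCCCC4)c3c2-c2ccc(Cl)cc2)cc1` differs from compound 3 by piperidin-1-yl in place of cyclohexylamino on an aromatic carbon. For the measured compounds named here, no measured step speaks to this change, and the single step among the fused compounds is unreadable. For this assay no direction beyond the scatter is therefore expected. Compound 4 is estimated at 60000 nM, between 20000 nM and 200000 nM. This estimate means an expected step that the limit leaves unreadable from compound 3 to compound 4.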

Compound 4, half-maximal inhibitory concentration: > 50000 nM
Compound 4 ended at the assay's limit (the forecaster's own chance of this, stated with the estimate: 80%); the middle value is on the limit's open side.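

No new step can be read between compound 4 and either compound 2 or compound 3, as all three sit at a limit and not at a number: the limit of > 50000 nM in this assay, at which 3 of the 4 values shown sit.

Going by these compounds, whether any group at this place on the shared core would give a measurable value in this assay stays open.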